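Allyl for propyl at the limit of the assay

This account rests on a few compounds, and the source may have more. Where it says the series, first, only, none or still open, it means among the compounds named here.

In a functional assay on HOS cells (Homo sapiens) for antiproliferative activity, read by sulforhodamine B assay (on this read-out higher numbers stand for weaker inhibition of growth and lower numbers for stronger inhibition of growth), compound 1 `CCC[C@@H]1O[C@H](COCc2ccccc2)[C@@H](OCc2ccccc2)[C@H](OCc2ccccc2)[C@H]1O` gives 38600 nM. Compound 2 `CCC[C@@H]1O[C@H](COCc2ccccc2)[C@@H](OCc2ccccc2)[C@H](OCc2ccccc2)C1=O` gives only > 50000 nM, which is a limit of the assay and not a number. Compound 3 `CCC[C@H]1O[C@H](COCc2ccccc2)[C@@H](OCc2ccccc2)[C@H](OCc2ccccc2)C1=O` gives > 50000 nM, which is likewise a limit. Compound 2 therefore has no exact place on the scale. Compound 4 `C=CC[C@@H]1O[C@H](COCc2ccccc2)[C@@H](OCc2ccccc2)[C@H](OCc2ccccc2)C1=O` differs from it by vinyl in place of ethyl on a saturated chain carbon bound to a saturated ring carbon, vinyl in place of ethyl, which cut one bond further out reads propyl to allyl. Going by the values given here, the only measured step that bears on this is a step that the two limits leave unreadable from compound 2 to compound 3, so it offers no size to carry over. In this assay the expected change is a number no higher from compound 2 to compound 4 (the limit leaves the size open), with no size beyond the scatter and no favoured direction. Compound 4 is estimated at 50000 nM, with an expected range from 25000 nM to 100000 nM.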

Compound 4, concentration for 50% growth inhibition: 7600 nM
The estimate for compound 4 lay 6.6-fold (0.82 log units) above the measured number; measured number below the stated range.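

In this assay, allyl in place of propyl gives an at least 6.5-fold lower number from compound 2 to compound 4 (0.81 log units; beyond the scatter). Going by these compounds alone, this is the first readable step at this saturated ring carbon's chain, and it shows that a change of this chain alone can bring the number down from the limit. Compound 2 holds a limit and not a number, so the size of this step has only a floor.

The step between the two drawn configurations cannot be read, because both compounds stand at a limit: the limit of > 50000 nM in this assay, at which 2 of the 4 values shown sit. As far as these compounds go, whether a longer chain or an amine at this place would lower the number further remains open.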